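The source may report more compounds than this note shows. Statements on the series, on what has been measured and on what is new or still open speak of the compounds shown alone.

Series notes. Among the measured compounds shown here, in a functional assay on Lu1 cells (Homo sapiens) for cytotoxicity, read by sulforhodamine B assay (a higher number here means that more compound is needed for the effect, a lower number that less compound is needed), compound 2 `C=C1CC[C@@H]2[C@](C)(CO[Si](C(C)C)(C(C)C)C(C)C)[C@H](OC(C)=O)CC[C@@]2(C)[C@@H]1C/C=C1/C(=O)OC[C@H]1OC(C)=O` gives 18.8 uM, the lowest of the three numbers so far. Compound 3 `C=C1CC[C@@H]2[C@](C)(CO[Si](C)(C)C(C)(C)C)[C@H](O)CC[C@@]2(C)[C@@H]1C/C=C1/C(=O)OC[C@H]1O` gives 48.8 uM and compound 1 `C=C1CC[C@@H]2[C@](C)(CO[Si](c3ccccc3)(c3ccccc3)C(C)(C)C)[C@H](OC(C)=O)CC[C@@]2(C)[C@@H]1C/C=C1/C(=O)OC[C@H]1OC(C)=O` gives 52.9 uM; both gaps to compound 2 are beyond the scatter, so compound 2 needs the least material of the three in this assay. The change from compound 2 to compound 4 `C=C1CC[C@@H]2[C@](C)(CO)[C@H](OC(C)=O)CC[C@@]2(C)[C@@H]1C/C=C1/C(=O)OC[C@H]1OC(C)=O` is a hydrogen atom in place of a group of 10 heavy atoms (9 carbon, 1 silicon; no ring), on an oxygen on a saturated carbon. For the measured compounds named here, no measured pair shows this change. Compound 1 and compound 3 sit close to each other in this assay, and only compound 2 stands lower. The step is expected to run toward a higher number, a 2.4-fold higher number from compound 2 to compound 4 (0.38 log units; beyond the scatter), beyond the scatter but modest. Compound 4 is therefore estimated at 45 uM, within the range 15 uM to 130 uM.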

Compound 4, concentration for half-maximal effect: 8.75 uM
Estimate against measurement, compound 4: 5.1-fold (0.71 log units) above; measured number below the stated range.
By their numbers in this assay, from the lowest: compound 4; then compound 2; then compounds 3 and 1 (each within the scatter of the next).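

On the oxygen on a saturated carbon, the group of 10 heavy atoms (9 carbon, 1 silicon; no ring) is not needed for the effect in this assay: a hydrogen atom in its place gives a 2.1-fold lower number from compound 2 to compound 4 (0.33 log units; beyond the scatter) and so keeps the effect with less compound. Among the compounds shown here, this is the only single-place step so far, and one pair shows no trend. Nothing available explains the step.

As far as these compounds go, whether a methyl ether or an acetate on this oxygen would stand nearer compound 4 or compound 2 remains open. Also open, from the compounds shown here alone, is whether the step holds on the core of compound 3.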